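Second Chloro on the Shared Core: Compound 3 Expected

The source may hold more compounds than are shown below. What is called first, only, known or untested is meant among the compounds shown, and "the series" means these compounds.

Going by the values given here, compound 1 `ClCc1ccc(Cn2cnc3c(Cl)ncnc32)cc1` in a functional assay on MDA-MB-231 cells (Homo sapiens) for cytotoxicity, read by sulforhodamine B assay, with a stated time of 48 h (a higher number here means a weaker inhibitor of growth, a lower number a stronger inhibitor of growth), gives 3890 nM, the highest of the two numbers so far. Compound 2 `ClCc1ccc(Cn2cnc3nc(Cl)nc(Cl)c32)cc1` in this assay gives 3090 nM, which lies within the scatter of compound 1. Compound 3 `ClCc1ccc(Cn2cnc3c(Cl)nc(Cl)nc32)cc1` differs from compound 1 by chloro in place of hydrogen on an aromatic carbon. Among the compounds with values here, no step between measured compounds matches this change; compound 2 also carries two chloro groups on its core and shows no separation from compound 1. The step from compound 1 to compound 3 is expected to stay within the scatter, a 1.3-fold lower number from compound 1 to compound 3 (0.10 log units; within the scatter), leaning slightly lower. Compound 3 is expected at 3100 nM, with a range of 1300 nM to 7500 nM.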

Compound 3, concentration for total growth inhibition: 3630 nM
For compound 3 the middle estimate is 1.2-fold (0.07 log units) below the measured one; low and high end bracket the measured number.
By their numbers in this assay, from the lowest: compounds 2, 3 and 1 (each within the scatter of the next).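

Chloro in place of hydrogen on an aromatic carbon between two ring nitrogen atoms gives a 1.1-fold lower number from compound 1 to compound 3 (0.03 log units; within the scatter) in this assay. Going by these compounds alone, this is the first single-place change read, and at this position, meta to a chloro group, the added chloro does not separate compound 3 from compound 1. No measurement at hand accounts for this result. On these data alone, whether an amine, a methoxy group or a longer chain at this position would separate from compound 1 stays open. As far as these compounds go, what replacing the chloromethyl group would do also stays open.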